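The source may hold more compounds than are shown below. What is called first, only, known or untested is meant among the compounds shown, and "the series" means these compounds.

Measured in an ADME assay on CCRF-HSB-2 cells (Homo sapiens) for cytotoxicity, with a stated time of 7 days; a higher number here means that more compound is tolerated, a lower number that less compound is tolerated:
- Compound 1 `C=CCOc1nc(N)nc2c1ncn2/C=C1/CC1(CO)CO`: > 20000 nM
- Compound 2 `Nc1nc(NC2CC2)c2ncn(/C=C3/CC3(CO)CO)c2n1`: > 20000 nM
- Compound 3 `CCCCCOc1nc(N)nc2c1ncn2/C=C1/CC1(CO)CO`: > 20000 nM

Each of these entries is a limit of the assay and not a number. Compound 3 therefore has no exact position among the others, and the whole set comes down to the limit of > 20000 nM in this assay, at which 3 of the 3 values shown sit.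

Compound 4 `CC(C)Sc1nc(N)nc2c1ncn2/C=C1/CC1(CO)CO` has not yet been measured. It differs from compound 3 by isopropylsulfanyl in place of pentyloxy on an aromatic carbon. In short, this is isopropylsulfanyl in place of pentyloxy on an aromatic carbon.

Three measured steps change the group on this same carbon: a step that the two limits leave unreadable from compound 1 to compound 2, a step that the two limits leave unreadable from compound 1 to compound 3 and a step that the two limits leave unreadable from compound 2 to compound 3. None of them has a size that can be read, so they offer no number to carry over. They show only that allyloxy, cyclopropylamino and pentyloxy all end at the same limit. For the measured compounds named here, no compound with a sulfur-linked group has been measured, so this expectation is a cautious one.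

No step beyond the scatter is expected in this assay, and no direction is favoured. The expected step is a step that the limit leaves unreadable from compound 3 to compound 4. For compound 4 the estimated half-maximal cytotoxic concentration is 25000 nM, with an expected range from 10000 nM to 60000 nM.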

Compound 4, half-maximal cytotoxic concentration: 94000 nM
For compound 4 the middle estimate is 3.8-fold (0.58 log units) below the measured one, outside the stated range (above it).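

In this assay, for the compounds shown here, no step to compound 4 can be read from compound 1, compound 2 or compound 3, since each of those three is recorded only as a limit: the limit of > 20000 nM in this assay, at which 3 of the 4 values shown sit. The compounds shown leave open whether isopropylsulfanyl on this aromatic carbon truly differs from allyloxy, cyclopropylamino or pentyloxy in how much compound is tolerated.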